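Widening the amine on a shared core: compound 1 to compound 3

The source may report more compounds than this note shows. Statements on the series, on what has been measured and on what is new or still open speak of the compounds shown alone.

Compound 1 `CN/C(C)=N/C1=Nc2ccccc2CS1` was examined in a functional assay (strain Wistar) with Rattus norvegicus as the target (a higher number here means that more compound is needed for the effect, a lower number that less compound is needed), where compound 1 gives 0.01 uM. Compound 2 `CCCN(CCC)/C(C)=N/C1=Nc2ccc(OC(F)(F)F)cc2CS1` differs from compound 1 in more than one place, and in this assay compound 2 gives 0.01 uM, level with compound 1 at the digits shown, so the two lie within the scatter of each other. Compound 3 `CCN(CC)/C(C)=N/C1=Nc2ccccc2CS1` has not yet been measured. It differs from compound 1 by a single change: diethylamino in place of methylamino on a carbon with a double bond to nitrogen. For the measured compounds named here, no measured pair shows this exact step on its own. Because compound 2 gives 0.01 uM and stays level with compound 1 despite a larger amine substituent among its differences, the step is expected to lie within the scatter, with no change in either direction beyond it: no change at the digits printed from compound 1 to compound 3 (within the scatter). Compound 3 is therefore estimated at 0.01 uM, with a range from 0.004 uM to 0.03 uM.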

Compound 3, minimum effective concentration: 0.1 uM
Compound 3: middle estimate off by 10-fold (1.00 log units), on the low side; the measured number lies above the stated range.
By their numbers in this assay, from the lowest: compounds 1 and 2 (each within the scatter of the next); then compound 3.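

In this assay, for the compounds shown here, diethylamino in place of methylamino on a carbon with a double bond to nitrogen gives a 10-fold higher number from compound 1 to compound 3 (1.00 log units; beyond the scatter) and this is the first reading of that change on its own, as the earlier pair differed in more than one place. The position is therefore not indifferent to the amine on this shared core. Going by these compounds alone, the single change also alters two counted features together, with more heavy atoms entering and the hydrogen-bond donor of methylamino leaving. Nothing in the data explains the shift.

The compounds shown leave open whether the added carbons or the lost donor matter more, a question that ethylamino or dimethylamino could help to separate. They also leave open how a ring amine such as pyrrolidine would read at this position.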